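Amide side chain series: from compound 2 to compound 3

The source may report more compounds than this note shows. Statements on the series, on what has been measured and on what is new or still open speak of the compounds shown alone.

Measured in a functional assay on A549 cells (Homo sapiens) for inhibition, read by sulforhodamine B assay, with a stated time of 72 h; on this read-out lower numbers stand for stronger inhibition of growth and higher numbers for weaker inhibition of growth:
- compound 1 `CNC(=O)/C=C/c1ccncc1-c1ccc2ccccc2c1`: 6620 nM
- compound 2 `CNC(=O)CCc1ccncc1-c1ccc2ccccc2c1`: 10400 nM

Within the data shown here, only two numbers exist so far. In this assay, among the measured compounds shown here, compound 2 gives 10400 nM, and its one neighbour, compound 1, lies within the scatter of it, so the two cannot be ranked. The next compound is compound 3 `CN(C)C(=O)/C=C/c1ccncc1-c1ccc2ccccc2c1`. The change is 2-(dimethylcarbamoyl)ethenyl in place of 2-(methylcarbamoyl)ethyl on an aromatic carbon.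

For the measured compounds named here, the one measured step that bears on this is a 1.6-fold higher number from compound 1 to compound 2 (0.20 log units; within the scatter), which exchanged the ethenyl form of the methylcarbamoyl chain for the ethyl form. That step was small, so the ethenyl part of the change gives no reason to expect a large shift. Going by the values given here, no measured pair shows what dimethylcarbamoyl does in place of methylcarbamoyl, and this leaves the range wide. A step within the scatter is expected, estimated as a 1.3-fold lower number from compound 2 to compound 3 (0.11 log units; within the scatter). The estimated value for compound 3 is 8000 nM, with an expected range of 3500 nM to 18000 nM.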

Compound 3, concentration for 50% growth inhibition: 5800 nM
Compound 3: the middle estimate sits 1.4-fold (0.14 log units) above what was measured; low and high end bracket the measured number.
By their numbers in this assay, from the lowest: compounds 3, 1 and 2 (each within the scatter of the next).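

In this assay, among these compounds, methyl in place of hydrogen on the amide-type nitrogen gives a 1.1-fold lower number from compound 1 to compound 3 (0.06 log units; within the scatter), the first measured change at this nitrogen, and it stays within the scatter even though the amide hydrogen is gone. The full change at this aromatic carbon, opposite the ring nitrogen, combines that methyl with the ethenyl form of the chain and gives a 1.8-fold lower number from compound 2 to compound 3 (0.25 log units; within the scatter), so even the two changes taken together stay within the scatter, and compound 1, compound 2 and compound 3 cannot be ranked. No measurement in hand offers an explanation for these small steps.

Going by these compounds, whether another end group on this chain, such as a carboxylic acid, an amine or a primary amide, or a longer chain would give a step beyond the scatter remains open. Also open, on these data alone, is how the ethyl form of the dimethylcarbamoyl chain would compare with compound 2 and compound 3, which would separate the methyl change from the ethenyl change on that side of the series.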